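Hydroxy in Place of Hydrogen on Compound 1

This account rests on a few compounds, and the source may have more. Where it says the series, first, only, none or still open, it means among the compounds named here.

Compound 1 (`C=C1C(=O)C2=C3[C@@H](CC[C@H]4C(=C)C(=O)O[C@@H]4[C@@H]13)CC[C@]21C(=O)C[C@H]2C(=C)CC[C@H]3C(=C)C(=O)O[C@@H]3[C@H]21`) gives > 10000 nM in a functional assay on PANC-1 cells (Homo sapiens) for cytotoxicity, read by CellTiter-Glo, with a stated time of 72 h (on this read-out lower numbers stand for stronger inhibition and higher numbers for weaker inhibition), a limit of the assay and not a number. Compound 1 thus sits at the limit: the limit of > 10000 nM in this assay, at which 1 of the 2 values shown sits. In this assay compound 2 (`C=C1C(=O)C2=C3[C@H](CC[C@H]4C(=C)C(=O)O[C@@H]4[C@@H]13)CC[C@@]21C(=O)C2=C3[C@H]1[C@H]1OC(=O)C(=C)[C@@H]1CC[C@@]3(O)CC[C@]21C(=O)C[C@H]2C(=C)CC[C@H]3C(=C)C(=O)O[C@@H]3[C@H]21`) gives 2500 nM. Compound 3 (`C=C1C(=O)C2=C3[C@H]1[C@H]1OC(=O)C(=C)[C@@H]1CC[C@]3(O)CC[C@]21C(=O)C[C@H]2C(=C)CC[C@H]3C(=C)C(=O)O[C@@H]3[C@H]21`) carries hydroxy in place of hydrogen on a saturated ring carbon. For the measured compounds named here, no measured pair shows this change. A small move toward stronger inhibition is expected, an at least 1.2-fold lower number from compound 1 to compound 3 (0.09 log units; that floor lies within the scatter), and compound 3 may also stay at the limit. For compound 3 the estimated value is 8000 nM, with an expected range of 3000 nM to 20000 nM.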

Compound 3, half-maximal inhibitory concentration: 2200 nM
Beside the measured number, compound 3's estimate is 3.6-fold (0.56 log units) above it; the whole stated range lies above it.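

Hydroxy in place of hydrogen on a saturated ring carbon, the first single change that can be read in this assay, gives an at least 4.5-fold lower number from compound 1 to compound 3 (0.65 log units; beyond the scatter). For the compounds shown here, the earlier compounds offered no pair for this change, so this is the first sign that this position responds to it. Compound 1 stands at a limit of the assay, so the step is a floor and its full size stays unknown: the limit of > 10000 nM in this assay, at which 1 of the 3 values shown sits.

Open, as far as these compounds go, is whether hydroxy alone lowers the number at this carbon, or whether methoxy or an amine there does the same.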